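The source may hold more compounds than are shown below. What is called first, only, known or untested is meant among the compounds shown, and "the series" means these compounds.

Measured compounds:
compound 1 `O=C(NOCc1ccccc1)c1cn(-c2ccccc2)nc1-c1ccccc1` — 8830 nM
compound 2 `O=C(NOCc1ccccc1F)c1cn(-c2ccccc2)nc1-c1ccccc1` — 11800 nM

For the measured compounds named here, in a functional assay on HeLa cells (Homo sapiens) for antiproliferative activity, read by MTT assay, with a stated time of 48 h, in the presence of a further agent that is not named here (on this read-out lower numbers stand for stronger inhibition of growth and higher numbers for weaker inhibition of growth), compound 1 shows the lowest of the two numbers, with compound 2 close by; the only measured step, a 1.3-fold higher number from compound 1 to compound 2 (0.13 log units; within the scatter), stays within the scatter, so the two cannot be ranked. Compound 3 `Cc1ccc(-c2nn(-c3ccccc3)cc2C(=O)NOCc2ccccc2)cc1` differs from compound 1 by methyl in place of hydrogen on an aromatic carbon, read one bond further out as phenyl to 4-methylphenyl. Going by the values given here, the single measured step concerns a different small change on another aromatic carbon and gave no shift beyond the scatter, so nothing here points to a large move in either direction. Compound 3 is therefore expected near 8000 nM, within 3000 nM to 20000 nM. The implied step, a 1.1-fold lower number from compound 1 to compound 3 (0.04 log units; within the scatter), is expected to remain within the scatter.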

Compound 3, concentration for 50% growth inhibition: 6690 nM
Compound 3: middle estimate off by 1.2-fold (0.08 log units), on the high side, within the range that was stated.
By their numbers in this assay, from the lowest: compounds 3, 1 and 2 (each within the scatter of the next).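

Going from phenyl to 4-methylphenyl gives, in this assay, a 1.3-fold lower number from compound 1 to compound 3 (0.12 log units; within the scatter) on the shared core, so this single methyl, on an aromatic carbon para to a large group, leaves the two compounds unranked. Together with the earlier fluoro step, this shows that a second small change, at a different aromatic carbon, also stays within the scatter. No measured information here accounts for this result.

Going by these compounds, whether an amine, a carboxylic acid or a longer chain at this place would move the number beyond the scatter stays open.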